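This account rests on a few compounds, and the source may have more. Where it says the series, first, only, none or still open, it means among the compounds named here.

In a functional assay on the whole organism with Rattus norvegicus as the target (on this read-out lower numbers stand for an effect already at smaller amounts and higher numbers for an effect only at larger amounts of compound), compound 2 `CCOCCOC(=O)C(=O)Nc1nc(-c2conc2C)cs1` stands at > 100 mg/kg as a limit, not a number. Compound 3 `CCOCCOC(=O)C(=O)Nc1nc(-c2c(-c3c(F)cccc3Cl)noc2C)cs1` sits at > 10 mg/kg as a limit too. Compound 1 `CCOCCOC(=O)C(=O)Nc1nc(-c2cc(Cl)no2)cs1` gives 6 mg/kg as a true number. Compound 4 `CCOCCOC(=O)C(=O)Nc1nc(-c2cc(CO)on2)cs1` departs from compound 2 through 5-(hydroxymethyl)-1,2-oxazol-3-yl in place of 3-methyl-1,2-oxazol-4-yl on an aromatic carbon on an aromatic carbon of the shared core. Going by the values given here, the one measured step at this place is an at least 16-fold higher number from compound 1 to compound 2 (1.22 log units; beyond the scatter) and it is large. It shows that the group here can move the dose widely, but neither of its two groups is the entering one, so only a moderate shift toward a lower number is expected. The expected change is an at least 3.3-fold lower number from compound 2 to compound 4 (0.52 log units; beyond the scatter) in this series. For compound 4 the estimate is 30 mg/kg with an expected range from 6 mg/kg to 150 mg/kg on this read-out.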

Compound 4, dose for half-maximal effect: 1.8 mg/kg
Compound 4: middle estimate off by 17-fold (1.22 log units), on the high side; the measured number lies below the stated range.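

In this assay this place on the shared core can also give a lower number, not only a higher one: 5-(hydroxymethyl)-1,2-oxazol-3-yl gives an at least 55-fold lower number from compound 2 to compound 4 (1.74 log units; beyond the scatter). Going by these compounds alone, the same group also outdoes 3-chloro-1,2-oxazol-5-yl, the only earlier group with a true number, with a 3.3-fold lower number from compound 1 to compound 4 (0.52 log units; beyond the scatter). Compound 2 enters the first step only as a limit: the limit of > 100 mg/kg in this assay, at which 1 of the 4 values shown sits.

The compounds shown do not separate the hydroxymethyl group from the change in how the ring is attached. Going by these compounds, whether an aminomethyl group or a carboxylic acid in place of the hydroxymethyl group would keep this low dose remains open.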